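The source may hold more compounds than are shown below. What is called first, only, known or untested is meant among the compounds shown, and "the series" means these compounds.

The series shares one core, carried in compound 1 `COc1ccc(NC(=O)Cn2cc(COc3ccc4c(c3)CCC4)nn2)cc1`, compound 2 `Cc1cc(C)c(-n2cc(COc3ccc4c(c3)CCC4)nn2)c(C)c1` and compound 3 `COc1cccc(NC(=O)Cn2cc(COc3ccc4c(c3)CCC4)nn2)c1`, which differ only in the group attached to the triazole. Within the data shown here, in an ADME assay on HEK293 cells (Homo sapiens) for inhibition, read by MTT assay, with a stated time of 48 h, tested at 25 uM (a lower number here means less inhibition, a higher number more inhibition at the concentration tested (going by the name of the read-out)), compound 2 gives 16.6%, the only number this set has to offer. Among the measured compounds shown here, for compound 1 the result in this assay is recorded as "not determined" (no result reported), and for compound 3 it is likewise "not determined" (no result reported), so no comparison between measured compounds is possible, and compound 2 stands alone as the sole point of reference.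

The next compound, compound 4 `Cc1ccc(-n2cc(COc3ccc4c(c3)CCC4)nn2)c(C)c1`, is reached from compound 2 by a single change: hydrogen in place of methyl on an aromatic carbon. The methyl that leaves sits on an aromatic carbon of a six-membered aromatic ring of carbon only, ortho to a large group and meta to two methyl groups. For the measured compounds named here, with no measured step available, the expectation rests only on the size of the change, which is one heavy atom. A shift in this assay, if any, is expected to stay within the usual scatter, with no clear direction, so the step from compound 2 to compound 4 is expected to be about a number 2.6 percentage points lower from compound 2 to compound 4 (within the scatter).

On that basis compound 4 is expected to give roughly 14% in this assay, within a range from 2% to 28%.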

Compound 4, a percentage reported as inhibition, at one concentration (the size of the read-out at that concentration, not a potency): 19.9%
Compound 4: middle estimate off by 5.9 percentage points, on the low side; the range from low to high includes it.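

Among these compounds, the step reads a number 3.3 percentage points higher from compound 2 to compound 4 (within the scatter) in this assay, and it is the first comparison in this set between two measured compounds that differ in one place. It shows that, on the aromatic carbon ortho to a large group and meta to two methyl groups, hydrogen in place of methyl gives a reading that cannot be told apart from that of compound 2, so at this one position and with this one exchange the assay does not separate the pair. Nothing available here bears on why the two readings fall so close together.

This single pair says nothing about groups other than methyl and hydrogen at this position, so an amine, a carboxylic acid or a longer chain on the same aromatic carbon could read quite differently in this assay. It also leaves open whether the two remaining methyl groups on the ring matter, since a compound with either of them replaced by hydrogen or by a methoxy group does not appear among those shown.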